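A few compounds are considered here, and "the series" means these few. Any claim that something is new, unique, unknown or untested is made for them only; others in the source may bear on it.

Measured so far, in an ADME assay on L6 cells (Rattus norvegicus) for cytotoxicity; a lower number here means a stronger inhibitor, a higher number a weaker inhibitor:

Compound 1 `CS[C@H]1O[C@@H](n2cnc3c(N)nc(I)nc32)[C@H](O)[C@@H]1O`: 137000 nM
Compound 2 `CS[C@H]1O[C@@H](n2cnc3c(N)nc(C#N)nc32)[C@H](O)[C@@H]1O`: 153000 nM
Compound 3 `CNc1nc(I)nc2c1ncn2[C@@H]1O[C@H](C)[C@@H](O)[C@H]1O`: 137000 nM

Compound 4 `CNc1nc(C#N)nc2c1ncn2[C@@H]1O[C@H](C)[C@@H](O)[C@H]1O` is not yet measured. From compound 1 to compound 2 the change is cyano in place of iodo on an aromatic carbon, and this step made a 1.1-fold higher number from compound 1 to compound 2 (0.05 log units; within the scatter). Compound 4 carries the same kind of change relative to compound 3, namely (cyano in place of iodo on an aromatic carbon); the surroundings of the place differ in that the carbon is meta to a methylamino group (2 heavy atoms) in compound 3, where in compound 1 it is meta to an amino group (1 heavy atom). The difference between the two cores, compound 1 against compound 3, is not broken down here. In this assay compound 3 stands level with compound 1, and compound 2 sits within the scatter of both. With one measured instance of the change at hand, the step for compound 4 is expected to be a 1.1-fold higher number from compound 3 to compound 4 (0.04 log units; within the scatter). This expectation rests on a 1.1-fold higher number from compound 1 to compound 2 (0.05 log units; within the scatter) and on compound 3 standing level with compound 1. Compound 4 is therefore estimated at 150000 nM, expected to fall between 90000 nM and 250000 nM.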

Compound 4, half-maximal inhibitory concentration: 85000 nM
Compound 4: the middle estimate sits 1.8-fold (0.25 log units) above what was measured; the measured number lies below the stated range.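

In this assay, putting cyano in place of iodo on the aromatic carbon gives a 1.6-fold lower number from compound 3 to compound 4 (0.21 log units; within the scatter), so this second instance of the change also stays inside the usual scatter. Set beside the first instance, the step does not separate the two cores: the same change on two cores in this assay, a 1.1-fold higher number (0.05 log units; within the scatter) from compound 1 to compound 2 and a 1.6-fold lower number (0.21 log units; within the scatter) from compound 3 to compound 4, 1.8-fold (0.26 log units) apart, within the scatter of two such steps. Among these compounds, this supports carrying the change between these two cores without a core-specific correction, but with only two pairs, each within the scatter, it shows neither that the change is without effect nor that the cores respond alike.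

Still open, going by these compounds, is whether the same holds for other groups on this carbon between two ring nitrogen atoms, such as a carboxylic acid or a primary amide, or with an ethylamino group or longer chain in place of the methylamino group. The compounds shown also leave open which of the differences between the core of compound 1 and the core of compound 3 would matter for a change with a step beyond the scatter.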